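A few compounds are considered here, and "the series" means these few. Any claim that something is new, unique, unknown or untested is made for them only; others in the source may bear on it.

Compound 3 `CCOc1ccccc1-n1nncc1CN1C(=O)C2(C(C#N)=C(N)Oc3c(N)cc4nc5ccccc5nc4c32)c2ccccc21` was tested in a functional assay on MCF7 cells (Homo sapiens) for antiproliferative activity, read by MTT assay, with a stated time of 48 h; on this read-out lower numbers stand for stronger inhibition and higher numbers for weaker inhibition. In this assay compound 3 gives > 50000 nM, which is a limit of the assay rather than a number. Two further compounds share the same core. Compound 1 `Cc1cc(C)cc(-n2nncc2CN2C(=O)C3(C(C#N)=C(N)Oc4c3c3nc5ccccc5nc3c3ccccc43)c3ccccc32)c1` gives > 50000 nM in this assay, again a limit. Compound 2 `N#CC1=C(N)Oc2c(c3nc4ccccc4nc3c3ccccc23)C12C(=O)N(Cc1cnnn1-c1ccc(F)c(Cl)c1)c1ccccc12` gives > 50000 nM in this assay, also a limit. Compound 3 therefore stands at the limit of > 50000 nM in this assay, at which 3 of the 3 values shown sit, with no measured number to set it apart from the others.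

Compound 4 `N#CC1=C(N)Oc2c(N)cc3nc4ccccc4nc3c2C12C(=O)N(Cc1cnnn1-c1ccc(Cl)cc1[N+](=O)[O-])c1ccccc12` differs from compound 3 in one place: 4-chloro-2-nitrophenyl in place of 2-ethoxyphenyl on an aromatic nitrogen. Within the data shown here, the only measured step at this same place is a step that the two limits leave unreadable from compound 1 to compound 2, and because both of its ends sit at the limit of > 50000 nM in this assay, at which 3 of the 3 values shown sit, its size cannot be read. Among the measured compounds shown here, no measured step thus gives a direction or a size for the change to compound 4, and the expectation is that the assay will again report only a limit. The estimate means a step that the limit leaves unreadable from compound 3 to compound 4. Compound 4 is expected to give 80000 nM, within a range from 30000 nM to 300000 nM.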

Compound 4, half-maximal inhibitory concentration: > 50000 nM
Compound 4: only a limit was reported; the forecaster's own chance of this, stated with the estimate: 85%; the middle value lies beyond the limit too.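

No step can be read from compound 3 to compound 4, because both sit at a limit of the assay rather than at a number: the limit of > 50000 nM in this assay, at which 4 of the 4 values shown sit.

The compounds shown leave open whether any group on the aromatic nitrogen gives a measurable value in this assay.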